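The compounds below may be only part of what the source reports. "The series", "measured", "known", "first", "only" and "open" are said of these compounds alone.

Measured so far:
compound 1 `COc1ccc(S(=O)(=O)NCCCCCCNCc2ccc(Br)cc2)cc1`: 13000 nM
compound 2 `O=[N+]([O-])c1ccccc1S(=O)(=O)NCCCCCCNCc1ccc(Br)cc1`: 11700 nM

In a functional assay on MIA PaCa-2 cells (Homo sapiens) for inhibition, read by MTT assay, with a stated time of 72 h (on this read-out higher numbers stand for weaker inhibition of growth and lower numbers for stronger inhibition of growth), compound 2 gives the lowest of the two numbers, with compound 1 within the scatter of it; the step from compound 1 to compound 2 was a 1.1-fold lower number from compound 1 to compound 2 (0.05 log units; within the scatter). Compound 3 `Cc1ccc(S(=O)(=O)NCCCCCCNCc2ccc(Br)cc2)cc1` differs from compound 2 by 4-methylphenyl in place of 2-nitrophenyl on a sulfonyl sulfur. Among the measured compounds shown here, the one measured step that bears on this position, from compound 1 to compound 2, also exchanged the group on the sulfonyl sulfur and stayed within the scatter, so no step beyond the scatter is expected in this assay here. Compound 3 is estimated at 12000 nM (6000 nM to 25000 nM), an expected step of a 1.0-fold higher number from compound 2 to compound 3 (0.01 log units; within the scatter).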

Compound 3, concentration for 50% growth inhibition: 12300 nM
For compound 3 the middle estimate is 1.0-fold (0.01 log units) below the measured one; low and high end bracket the measured number.
By their numbers in this assay, from the lowest: compounds 2, 3 and 1 (each within the scatter of the next).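

In this assay 4-methylphenyl in place of 2-nitrophenyl on the sulfonyl sulfur gives a 1.1-fold higher number from compound 2 to compound 3 (0.02 log units; within the scatter) even though the entering group has no hydrogen-bond acceptors and the leaving group has them. Methyl in place of methoxy on an aromatic carbon gives a 1.1-fold lower number from compound 1 to compound 3 (0.02 log units; within the scatter) and so adds a second exchange that stays within the scatter. No evidence on hand bears on this result.

Still open, on these data alone, is whether a carboxylic acid or an amine on the aromatic ring would give a step beyond the scatter. As far as these compounds go, a longer chain in the shared core also remains open.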